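A few compounds are considered here, and "the series" means these few. Any claim that something is new, unique, unknown or untested is made for them only; others in the source may bear on it.

In a functional assay on MV4-11 cells (Homo sapiens) for inhibition, read by resazurin assay, with a stated time of 72 h (on this read-out lower numbers stand for stronger inhibition of growth and higher numbers for weaker inhibition of growth), compound 1 `COc1ccc(Nc2nccc(-c3cn(C)c4ccccc34)n2)c(OC)c1` gives 3410 nM. Among the compounds with values here, compound 2 `CCCn1cc(-c2ccnc(Nc3ccc(OC)cc3OC)n2)c2ccccc21` gives 3620 nM, so compound 2 stands level with the only other measured compound, and these two numbers cannot be told apart. The next structure, compound 3 `COc1ccc(Nc2nccc(-c3cn(C4CCCC4)c4ccccc34)n2)c(OC)c1`, has cyclopentyl in place of propyl on an aromatic nitrogen. Within the data shown here, only one measured step bears on this change, because it alters a group on the same nitrogen: a 1.1-fold higher number from compound 1 to compound 2 (0.03 log units; within the scatter). That step stays within the scatter, so the change of group between compound 1 and compound 2 left no visible mark on growth inhibition. It is a thin guide, however. It is a single step, and neither measured compound carries a ring at this place. No shift beyond the scatter is therefore expected in this assay, and neither direction is favoured. The expected size of the change is a 1.0-fold lower number from compound 2 to compound 3 (0.01 log units; within the scatter). Compound 3 is estimated at 3500 nM, with an expected range from 1500 nM to 8000 nM, kept wide because so little evidence stands behind it.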

Compound 3, concentration for 50% growth inhibition: 1740 nM
Compound 3: the middle estimate sits 2.0-fold (0.30 log units) above what was measured; the range from low to high includes it.
By their numbers in this assay, from the lowest: compounds 3, 1 and 2 (each within the scatter of the next, the first and the last beyond it).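

In this assay, within the data shown here, cyclopentyl in place of propyl on the aromatic nitrogen gives a 2.1-fold lower number from compound 2 to compound 3 (0.32 log units; beyond the scatter) as a modest step, the first change in this small set to pass beyond the scatter, so what this nitrogen carries can make a visible difference to growth inhibition. The signal is limited, however: cyclopentyl in place of methyl gives a 2.0-fold lower number from compound 1 to compound 3 (0.29 log units; within the scatter) and stays within the scatter, so compound 3 can be told apart from compound 2 but not from compound 1, and the three compounds form no clear trend with group size. Nothing among the data shown explains the step between propyl and cyclopentyl.

Propyl and cyclopentyl differ both in carbon count and in the presence of a ring, so these compounds cannot show which of the two differences matters, if either does. Also open, from the compounds shown here alone, is how growth inhibition would respond to a pentyl chain, a cyclohexyl ring or a chain ending in an amine on this same nitrogen.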